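A few compounds are considered here, and "the series" means these few. Any claim that something is new, unique, unknown or untested is made for them only; others in the source may bear on it.

Two compounds built on a shared core have been taken through a functional assay on the whole organism with Rattus norvegicus as the target; a lower number here means that less compound is needed, a higher number that more compound is needed for the effect. Compound 1, `Nc1nc2cccc(OC(F)(F)F)c2s1`, is one of them. In this assay compound 1 reaches only a limit of the assay, > 10 mg/kg, and no number. Compound 2, `CCCCn1c(=N)sc2cc(OC(F)(F)F)ccc21`, is the other. In this assay compound 2 gives 10 mg/kg. For the measured compounds named here, of the two results, compound 2 holds the only number; the other result is a limit, as the limit of > 10 mg/kg in this assay, at which 1 of the 2 values shown sits, records. Nothing more can be said of the gap between compound 1 and compound 2 than what those two readings show. Compound 3, `CS(=O)(=O)CCn1c(=N)sc2cc(OC(F)(F)F)ccc21`, has not been measured. It differs from compound 2 in one place: methylsulfonyl in place of ethyl on a saturated chain carbon, two bonds along the chain from an aromatic nitrogen. The rest of the structure is kept. Going by the values given here, with no measured step of this kind to lean on, a small step in this assay is expected, in neither direction clearly beyond the scatter, and a result reported only as a limit cannot be ruled out. The expected step is no change at the digits printed from compound 2 to compound 3 (within the scatter). For compound 3 the expected dose in this assay is 10 mg/kg, within a range from 3 mg/kg to 30 mg/kg.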

Compound 3, dose for half-maximal effect: 1.8 mg/kg
Beside the measured number, compound 3's estimate is 5.6-fold (0.74 log units) above it, and the stated range ends above it.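

In this assay, for the compounds shown here, the earlier compounds offered no step at this place, and the first one now shows that the chain on the aromatic nitrogen is a place where a change registers: methylsulfonyl in place of ethyl, on a saturated chain carbon two bonds along the chain from an aromatic nitrogen, gives a 5.6-fold lower number from compound 2 to compound 3 (0.74 log units; beyond the scatter). Read one bond further out, the same difference is butyl to 2-(methylsulfonyl)ethyl, so a chain end with 4 heavy atoms and 2 hydrogen-bond acceptors is not only accepted here but goes with a smaller dose than the plain butyl chain. Nothing in the data at hand accounts for why this change lowers the number.

This is a single step in a single assay, so it does not show whether the sulfonyl group itself matters or whether any other chain end would do the same. On these data alone, what a carboxylic acid, an amine, a methoxy group or a longer butyl-based chain would give at this place remains open, as does whether methylsulfonyl would give a similar step on a chain of another length.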